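Compound 3: hydrogen in place of methoxy

The source may report more compounds than this note shows. Statements on the series, on what has been measured and on what is new or still open speak of the compounds shown alone.

Measured so far:
compound 1 `COc1cccc(-c2ncnn2-c2cc(OC)c(OC)c(OC)c2)c1`: > 10000 nM (a limit, not a number)
compound 2 `CCOc1ccc(-c2ncnn2-c2cc(OC)c(OC)c(OC)c2)cc1Cl`: 3 nM

Both values come from a functional assay on HL-60 cells (Homo sapiens) for antiproliferative activity, read by MTT assay, with a stated time of 72 h; a lower number here means a stronger inhibitor, a higher number a weaker inhibitor. Compound 1 has no number on this read-out, only a limit at > 10000 nM. That position is recorded as the limit of > 10000 nM in this assay, at which 1 of the 2 values shown sits. Compound 2 gives a measured value of 3 nM. Among the measured compounds shown here, the series so far holds no measured step confined to one place, so any expectation here is loosely anchored.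

The unmeasured compound 3 `COc1cc(-n2ncnc2-c2ccccc2)cc(OC)c1OC` has hydrogen in place of methoxy on an aromatic carbon, meta to a large group, which reads as 3-methoxyphenyl to phenyl: hydrogen in place of methoxy on an aromatic carbon.

In this assay, only a small step is expected, if any, and its direction would be toward a stronger inhibitor. The expectation rests on compound 1, which offers only the limit > 10000 nM as a starting point. A second limit for compound 3 is quite possible. The estimated change is an at least 1.2-fold lower number from compound 1 to compound 3 (0.09 log units; that floor lies within the scatter), and it is expected to stay small. The estimate for compound 3 is 8000 nM, expected within 1500 nM to 30000 nM.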

Compound 3, half-maximal inhibitory concentration: > 10000 nM
Compound 3: a limit, no number; the forecaster's own chance of this, stated with the estimate: 60%; middle value at least 1.2-fold (0.09 log units) away from the limit.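

In this assay compound 1 and compound 3 each stand as a limit, not a number, so hydrogen in place of methoxy gives no readable step between them: the limit of > 10000 nM in this assay, at which 2 of the 3 values shown sit. The compounds shown leave open how far either compound lies past that limit, and whether this exchange shifts the read-out at all.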